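Swapping the aryl group on a shared core

The compounds below may be only part of what the source reports. "The series", "measured", "known", "first", "only" and "open" are said of these compounds alone.

Compound 1 `CNC(=O)c1cc(Oc2ccc(NC(=O)c3nn(-c4cccc(F)c4)c(=O)cc3C)cc2F)ccn1`: 10200 nM
Compound 2 `Cc1cc(=O)n(-c2cccc(F)c2)nc1C(=O)Nc1ccc(Oc2ncnc3ccsc23)cc1`: 10200 nM

Both compounds were tested in a functional assay on HepG2 cells (Homo sapiens) for cytotoxicity, read by MTT assay, with a stated time of 72 h; on this read-out lower numbers stand for stronger inhibition and higher numbers for weaker inhibition. Compound 1 gives 10200 nM, and compound 2 gives 10200 nM; the two numbers are level at the digits shown, and no single-point step connects them, so nothing more than this likeness can be read from the pair. Compound 3 `Cc1ccc(-n2nc(C(=O)Nc3ccc(Oc4ncnc5ccsc45)cc3)c(C)cc2=O)c(C)c1` differs from compound 2 in one place: 2,4-dimethylphenyl in place of 3-fluorophenyl on an aromatic nitrogen. For the measured compounds named here, no measured pair of compounds shows a change of this kind, so there is no direct guide to its effect. The step that is expected, a 1.0-fold lower number from compound 2 to compound 3 (0.01 log units; within the scatter), is none beyond the scatter in either direction. Compound 3 is therefore estimated at 10000 nM in this assay, within a range from 4000 nM to 30000 nM, with the upper end left wide.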

Compound 3, half-maximal inhibitory concentration: 17900 nM
Beside the measured number, compound 3's estimate is 1.8-fold (0.25 log units) below it; measured number inside the range.
By their numbers in this assay, from the lowest: compounds 1, 2 and 3 (each within the scatter of the next).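

For the compounds shown here, this is the first measured change at the aryl group on the aromatic nitrogen: in this assay, 2,4-dimethylphenyl in place of 3-fluorophenyl gives a 1.8-fold higher number from compound 2 to compound 3 (0.24 log units; within the scatter) on the shared core. At this position, then, losing the fluorine and gaining two methyl groups leaves a difference that cannot be told apart from the ordinary spread of repeated measurements, so this swap on its own gives no clear signal in either direction. No measurement shown bears on the reason for this result.

As far as these compounds go, it remains open whether a phenyl ring carrying a single methyl group would read the same way as the two-methyl version. From the compounds shown here alone, it is also open whether a more different substituent on that aryl ring, such as an amine or a carboxylic acid, would move the number beyond that spread.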